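A few compounds are considered here, and "the series" means these few. Any claim that something is new, unique, unknown or untested is made for them only; others in the source may bear on it.

Compound 1 `C=C1C[C@]23C[C@@]1(O)CC[C@H]2c1ccc(OS(=O)(=O)c2ccc(C)cc2)c(C)c1[C@@H]3Cn1cc(-c2ccc(Cl)cc2)nn1` has been examined in a functional assay on A549 cells (Homo sapiens) for cytotoxicity, read by MTT assay, with a stated time of 4 days; a lower number here means a stronger inhibitor, a higher number a weaker inhibitor. In this assay compound 1 gives only a limit of the assay, > 20000 nM, and no number. Compound 3 `Cc1c(O)ccc2c1[C@H](Cn1cc(-c3ccccn3)nn1)[C@@]13CC(=O)[C@@](C)(CC[C@@H]21)C3` likewise gives only a limit in this assay, namely > 20000 nM. Among the measured compounds shown here, compound 2 `C=C1C[C@]23C[C@@]1(O)CC[C@H]2c1ccc(O)c(C)c1[C@@H]3Cn1cc(-c2ccc(C(F)(F)F)cc2)nn1` is the one compound with a number, giving 10400 nM in this assay. For the measured compounds named here, compound 1 therefore stands at the limit of > 20000 nM in this assay, at which 2 of the 3 values shown sit, so nothing can be said about how it orders against the other two compounds, and no pair of measured compounds differs in a single place, so no measured step is available to guide the change that follows.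

Compound 4 `C=C1C[C@]23C[C@@]1(O)CC[C@H]2c1ccc(OS(=O)(=O)c2ccc(C)cc2)c(C)c1[C@@H]3Cn1cc(-c2ccc(C)cc2)nn1` is yet to be measured in this assay. It differs from compound 1 by methyl in place of chloro on an aromatic carbon. Going by the values given here, with no measured step to rest on, the expected step is a step that the limit leaves unreadable from compound 1 to compound 4, which is none beyond the scatter. Compound 4 is therefore estimated to give about 25000 nM in this assay, between 8000 nM and 60000 nM, and it is expected most likely to be reported again only as a limit.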

Compound 4, half-maximal inhibitory concentration: > 20000 nM
Compound 4: only a limit was reported; the forecaster's own chance of this, stated with the estimate: 70%; the middle value is on the limit's open side.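

Compound 4, like compound 1, gives only a limit in this assay and no number, so no step between the two can be read: the limit of > 20000 nM in this assay, at which 3 of the 4 values shown sit.

The compounds shown leave open whether methyl in place of chloro changes the cytotoxicity of this core at all.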